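Adding a methyl to the pyrimidin-5-yl of compound 3

A few compounds are considered here, and "the series" means these few. Any claim that something is new, unique, unknown or untested is made for them only; others in the source may bear on it.

The series is followed in an ADME assay on cells for inhibition of cytochrome P450 11B1, mitochondrial (Homo sapiens), read by HPLC, with a stated time of 60 min; on this read-out higher numbers stand for weaker inhibition and lower numbers for stronger inhibition. Compound 1 `Fc1ccc2nc(-n3ccnn3)n(C3CC3)c2c1` gives 9070 nM. Compound 2 `Fc1ccc2nc(-c3cncnc3)n(C3CC3)c2c1` gives 5380 nM; the step is a 1.7-fold lower number from compound 1 to compound 2 (0.23 log units; within the scatter). Compound 3 `Fc1cc2nc(-c3cncnc3)n(C3CC3)c2cc1F` gives 2270 nM, the lowest of the three numbers; the step is a 2.4-fold lower number from compound 2 to compound 3 (0.37 log units; beyond the scatter), and the gap to compound 1 is wider still.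

Compound 4 `Cc1ncncc1-c1nc2cc(F)c(F)cc2n1C1CC1` is not yet measured. It differs from compound 3 by methyl in place of hydrogen on an aromatic carbon. Neither measured step bears directly on this change: the step from compound 1 to compound 2 exchanges one ring for another, and the step from compound 2 to compound 3 adds a fluoro to the shared core, not a methyl to the pyrimidin-5-yl ring. Both measured steps were small, one within the scatter and one modestly beyond it, so in this assay no step beyond the scatter is expected, and the estimated step from compound 3 to compound 4 is a 1.1-fold lower number from compound 3 to compound 4 (0.05 log units; within the scatter). Compound 4 is therefore expected to give about 2000 nM, with a range from 800 nM to 5000 nM.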

Compound 4, half-maximal inhibitory concentration: 4160 nM
Beside the measured number, compound 4's estimate is 2.1-fold (0.32 log units) below it; low and high end bracket the measured number.
By their numbers in this assay, from the lowest: compounds 3, 4, 2 and 1 (each within the scatter of the next, the first and the last beyond it).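

In this assay, methyl in place of hydrogen on the pyrimidin-5-yl, on the aromatic carbon next to the ring nitrogen and ortho to a large group, gives a 1.8-fold higher number from compound 3 to compound 4 (0.26 log units; within the scatter) and so stays inside the usual scatter. Within the data shown here, this is the first look at a substituent on this ring, since the earlier steps exchanged the ring itself or added a fluoro to the shared core, and at this place the read-out does not separate 4-methylpyrimidin-5-yl from pyrimidin-5-yl. No measurement at hand speaks to what lies behind this reading.

Methyl is the only group shown at this place, so an ethyl, a methoxy or an amine there remains open. Also open, from the compounds shown here alone, is whether the methyl reads the same on the core of compound 2, which carries one fluoro fewer.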